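Removal of the fluoro from the phenylpiperazine arm

The source may hold more compounds than are shown below. What is called first, only, known or untested is meant among the compounds shown, and "the series" means these compounds.

Working notes on the series. Compound 3 `Nc1scc(CN2CCN(c3ccc(F)c(Cl)c3)CC2)c1C(=O)c1ccc(Cl)cc1` stands lowest of the three compounds measured in a functional assay on CHO cells with adenosine receptor A1 (Homo sapiens) as the target, read by cAMP accumulation and immunoassay, with a stated time of 6 min, tested at 10 uM (on this read-out higher numbers stand for a weaker effect at the one concentration tested and lower numbers for a stronger effect), where compound 3 gives -78%. Compound 1 `Nc1scc(CN2CCN(c3ccc(Cl)cc3Cl)CC2)c1C(=O)c1ccc(Cl)cc1` gives -74% in this assay, and compound 2 `Nc1scc(CN2CCN(c3ccncc3)CC2)c1C(=O)c1ccc(Cl)cc1` gives -15%. The step of a number 4 percentage points lower from compound 1 to compound 3 (within the scatter) is small, whereas a number 59 percentage points higher from compound 1 to compound 2 (beyond the scatter) and a number 63 percentage points lower from compound 2 to compound 3 (beyond the scatter) are large; the two compounds carrying a halogenated phenyl group on the amine nitrogen in the ring sit together, and the pyridin-4-yl compound sits apart.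

Compound 4 `Nc1scc(CN2CCN(c3cccc(Cl)c3)CC2)c1C(=O)c1ccc(Cl)cc1` differs from compound 3 by hydrogen in place of fluoro on an aromatic carbon, so the arm reads 3-chlorophenyl instead of 3-chloro-4-fluorophenyl. Within the data shown here, no measured step removes a single halogen from this phenyl ring; the only step between two halogenated phenyl groups is a number 4 percentage points lower from compound 1 to compound 3 (within the scatter), which lies within the scatter. A step of similar size is therefore expected, with the expected change a number 8 percentage points higher from compound 3 to compound 4 (within the scatter) not beyond the scatter. For compound 4 the estimated value in this assay is -70%, with a range from -88% to -45%.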

Compound 4, a percentage reported as activity, at one concentration (the size of the read-out at that concentration, not a potency): -77%
Compound 4: the middle estimate sits 7 percentage points above what was measured; the range from low to high includes it.
By their numbers in this assay, from the lowest: compounds 3, 4 and 1 (each within the scatter of the next); then compound 2.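

Among these compounds, removing the fluoro from the aromatic carbon para to a large group and ortho to a chloro group leaves this assay unchanged within the scatter, with a number 1 percentage points higher from compound 3 to compound 4 (within the scatter) as the first step to take a single halogen off this phenyl ring. The 3-chlorophenyl arm also stays level with the 2,4-dichlorophenyl arm (a number 3 percentage points lower from compound 1 to compound 4 (within the scatter)) and apart from the pyridin-4-yl arm (a number 62 percentage points lower from compound 2 to compound 4 (beyond the scatter)), so compound 1, compound 3 and compound 4 sit together, and compound 2 goes against them. Nothing at hand accounts for this result.

From the compounds shown here alone, what a methoxy, a nitrile or an amine would do on this aromatic carbon stays open. So does the read-out of a plain phenyl arm with no chloro on the ring.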